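A few compounds are considered here, and "the series" means these few. Any claim that something is new, unique, unknown or untested is made for them only; others in the source may bear on it.

Measured so far:
compound 1 `N#CSc1c(-c2ccccc2)nc2sc(Cc3ccccc3)nn12` — 7400 nM
compound 2 `O=Cc1c(-c2ccc([N+](=O)[O-])cc2)nc2sc(Cc3ccccc3)nn12` — 2800 nM

In a functional assay on cells (Cancer cell lines, Homo sapiens) for inhibition (on this read-out higher numbers stand for weaker inhibition of growth and lower numbers for stronger inhibition of growth), compound 2 gives the lower of the two numbers; compound 1 gives a number beyond the scatter above it, yet the two compounds differ in more than one place, so no single step can be read from them. Compound 3 `O=[N+]([O-])c1ccc(-c2nc3sc(Cc4ccccc4)nn3c2Br)cc1` differs from compound 2 in one place only: bromo in place of formyl on an aromatic carbon. Among the measured compounds shown here, no measured pair shows this exchange, so its size is unknown; a step within the scatter, in either direction, seems the most likely outcome. For compound 3 in this assay a value near 3500 nM is expected, within 1000 nM to 12000 nM, amounting to an expected step of a 1.3-fold higher number from compound 2 to compound 3 (0.10 log units; within the scatter).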

Compound 3, concentration for 50% growth inhibition: 17400 nM
Estimate against measurement, compound 3: 5.0-fold (0.70 log units) below; measured number above the stated range.
By their numbers in this assay, from the lowest: compound 2; then compound 1; then compound 3.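

In this assay this aromatic carbon is sensitive to the group it carries: bromo in place of formyl gives a 6.2-fold higher number from compound 2 to compound 3 (0.79 log units; beyond the scatter), a step beyond the usual scatter. Growth inhibition therefore weakens when the formyl, with its hydrogen-bond acceptor, gives way to a single bromine atom. No measurement shown here accounts for the size of this step. As far as these compounds go, it remains open whether an amine or a carboxylic acid on this carbon would give a number closer to compound 2 or to compound 3. Whether the same exchange has a similar effect without the nitro group on the phenyl ring is also unknown.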